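The compounds below may be only part of what the source reports. "The series", "measured", "known", "first", "only" and "open" are said of these compounds alone.

Three compounds of this series have so far been run through a functional assay on T47D cells (Homo sapiens) for inhibition, read by sulforhodamine B assay, with a stated time of 48 h; on this read-out higher numbers stand for weaker inhibition of growth and lower numbers for stronger inhibition of growth. Compound 1 `COc1cc(-c2cc(/C=C/C(=O)c3ccc(N)cc3)[nH]n2)cc(OC)c1OC` gives 1420 nM. Compound 2 `COc1ccc(C(=O)/C=C/c2cc(-c3cc(OC)c(OC)c(OC)c3)n[nH]2)cc1OC` gives 1630 nM. Compound 3 `COc1cc(-c2cc(/C=C/C(=O)c3ccc(F)c(F)c3)[nH]n2)cc(OC)c1OC` gives 2450 nM. On these numbers compound 2 stands second highest of the three, its nearest neighbour being compound 1 and its furthest compound 3, and both gaps fall within the scatter. The steps that connect the three all exchange the aryl on the carbonyl carbon: a 1.1-fold higher number from compound 1 to compound 2 (0.06 log units; within the scatter), a 1.7-fold higher number from compound 1 to compound 3 (0.24 log units; within the scatter) and a 1.5-fold higher number from compound 2 to compound 3 (0.18 log units; within the scatter). None of them reaches beyond the scatter, so the aryl on the carbonyl carbon, as far as these three compounds show, hardly moves the number in this assay.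

Compound 4 `COc1cc(C(=O)/C=C/c2cc(-c3cc(OC)c(OC)c(OC)c3)n[nH]2)cc(OC)c1OC` has not yet been measured in this assay. It differs from compound 2 in one place: methoxy in place of hydrogen on an aromatic carbon, entering on an aromatic carbon of a six-membered aromatic ring of carbon only, ortho to a methoxy group and meta to a large group and to a methoxy group. Going by the values given here, the steps that bear on this change are the three above, all of them within the scatter, and they again touch only the aryl on the carbonyl carbon. No step beyond the scatter is therefore expected in this assay in either direction. Compound 4 is estimated to give 1600 nM in this assay, with a range from 700 nM to 3600 nM. The estimated step, a 1.0-fold lower number from compound 2 to compound 4 (0.01 log units; within the scatter), is expected to stay within the scatter.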

Compound 4, concentration for 50% growth inhibition: 1130 nM
The estimate for compound 4 lay 1.4-fold (0.15 log units) above the measured number; measured number inside the range.
By their numbers in this assay, from the lowest: compounds 4, 1, 2 and 3 (each within the scatter of the next, the first and the last beyond it).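

In this assay the exchange of hydrogen for methoxy gives a 1.4-fold lower number from compound 2 to compound 4 (0.16 log units; within the scatter) and so stays within the scatter, like the three earlier steps. Going by these compounds alone, this is the first step to change a single aromatic carbon instead of exchanging the whole aryl on the carbonyl carbon, and the position, ortho to a methoxy group and meta to a large group and to a methoxy group, accepts a methoxy group without a step beyond the scatter. No measurement at hand accounts for this outcome or shows what the added methoxy group does at this position.

From the compounds shown here alone, whether this position stays as undemanding with other groups remains open, for instance with an amine, a carboxylic acid, a chlorine atom or an ethoxy chain in place of the methoxy group in this assay and with the rest of compound 4 kept unchanged. Going by these compounds, the shared core stays the same throughout, so it also remains open how the number responds when one of the methoxy groups of the core of compound 4 gives way to a hydroxyl group or to a hydrogen atom.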